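The source may hold more compounds than are shown below. What is called first, only, known or untested is meant among the compounds shown, and "the series" means these compounds.

Working notes on the series built on the core of compound 1 `CCCCCCCCCCCCNc1nc(SCc2ccc(C(F)(F)F)cc2)nc2ccccc12`, all tested in a functional assay on HGC-27 cells (Homo sapiens) for cytotoxicity, read by MTT assay, with a stated time of 72 h; on this read-out lower numbers stand for stronger inhibition and higher numbers for weaker inhibition. Compound 1 gives 38700 nM in this assay. Compound 2 `COc1ccccc1Nc1nc(SCc2ccc(C(F)(F)F)cc2)nc2ccccc12` reaches only the limit of the assay, > 50000 nM, and no number of its own. Compound 3 `CCOc1ccccc1Nc1nc(SCc2ccc(C(F)(F)F)cc2)nc2ccccc12` likewise returns only a limit, > 50000 nM. Among the compounds with values here, the single step between measured neighbours, a step that the two limits leave unreadable from compound 2 to compound 3, is hence of unreadable size, both ends resting at the limit of > 50000 nM in this assay, at which 2 of the 3 values shown sit. Compound 2 therefore stands at the limit, with compound 3 beside it there and only compound 1 carrying a number in this assay.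

Compound 4 `FC(F)(F)c1ccc(CSc2nc(Nc3ccc(Cl)cc3)c3ccccc3n2)cc1` differs from compound 2 by 4-chlorophenyl in place of 2-methoxyphenyl on a nitrogen on an aromatic ring. Within the data shown here, no measured step bears on this change, and the one step available, a step that the two limits leave unreadable from compound 2 to compound 3, offers no size to lean on. The whole series sits at or near the limit, so the expectation for compound 4 is for a value close to it, in either direction, or none beyond the scatter. Compound 4 is estimated at 40000 nM, with a range from 10000 nM to 90000 nM, which is an expected step of an at least 1.2-fold lower number from compound 2 to compound 4 (0.09 log units; that floor lies within the scatter).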

Compound 4, half-maximal inhibitory concentration: 14100 nM
Compound 4: the middle estimate sits 2.8-fold (0.45 log units) above what was measured; measured number inside the range.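

In this assay the aromatic group on this nitrogen proves able to move the read-out: 4-chlorophenyl in place of 2-methoxyphenyl gives an at least 3.5-fold lower number from compound 2 to compound 4 (0.54 log units; beyond the scatter), and 4-chlorophenyl in place of 2-ethoxyphenyl gives an at least 3.5-fold lower number from compound 3 to compound 4 (0.54 log units; beyond the scatter). Of the three compounds with an aromatic ring on this nitrogen, only compound 4 carries a number of its own, 14100 nM. Both steps are floors and their full size stays unknown, because compound 2 and compound 3 each rest at a limit rather than a number: the limit of > 50000 nM in this assay, at which 2 of the 4 values shown sit.

The change replaces the substituent and its ring position together, so the shift cannot be assigned to the chlorine, to the loss of the alkoxy group or to the new position. A plain phenyl, a 2-chlorophenyl or a 4-methoxyphenyl group on this nitrogen would separate these readings.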